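The source may hold more compounds than are shown below. What is called first, only, known or untested is meant among the compounds shown, and "the series" means these compounds.

In a physicochemical assay for solubility, read by LC-MS, measured as kinetic solubility, with a stated time of 1 h (on this read-out lower numbers stand for lower solubility and higher numbers for higher solubility), compound 1 `CCn1cc(Nc2nc(N)nc(-c3cccc(-n4ccc5cc(C6CC6)cc(F)c5c4=O)c3CO)n2)cc1C#N` gives 710 nM, while compound 2 `Nc1nc(Nc2cnn(C3CC3)c2)nc(-c2cccc(-n3ccc4cc(C5CC5)cc(F)c4c3=O)c2CO)n1` gives 4700 nM, the higher of the two numbers shown; the one measured step, a 6.6-fold higher number from compound 1 to compound 2 (0.82 log units; beyond the scatter), lies between them. Compound 3 `Nc1nc(Nc2cn[nH]c2)nc(-c2cccc(-n3ccc4cc(C5CC5)cc(F)c4c3=O)c2CO)n1` differs from compound 2 by hydrogen in place of cyclopropyl on an aromatic nitrogen. Going by the values given here, no measured step covers this exact change, and the single known step concerns a different group exchange, so the expectation rests on compound 2 alone. A modest rise of a 1.9-fold higher number from compound 2 to compound 3 (0.28 log units; within the scatter) is expected rather than no step beyond the scatter. Compound 3 is therefore estimated at 9000 nM, within a range of 3000 nM to 27000 nM.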

Compound 3, solubility: 12000 nM
Estimate against measurement, compound 3: 1.3-fold (0.12 log units) below; the measured number falls inside the stated range.
By their numbers in this assay, from the lowest: compound 1; then compound 2; then compound 3.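

With hydrogen in place of cyclopropyl on the aromatic nitrogen, this assay shows a 2.6-fold higher number from compound 2 to compound 3 (0.41 log units; beyond the scatter) at this one position, where the earlier step had exchanged the entire group on the nitrogen. Against the 5-cyano-1-ethyl-1H-pyrrol-3-yl group, 1H-pyrazol-4-yl gives a 17-fold higher number from compound 1 to compound 3 (1.23 log units; beyond the scatter) as the largest step shown. Nothing measured here accounts for either step. Still open, going by these compounds, is where a methyl group or a longer chain on this nitrogen would fall relative to hydrogen and cyclopropyl. Also open, on these data alone, is how a chain ending in an amine would read there.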